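Trimming the sulfonyl substituent of compound 3 to methylsulfonyl

The source may report more compounds than this note shows. Statements on the series, on what has been measured and on what is new or still open speak of the compounds shown alone.

Compound 3 `Cn1ccnc1CS(=O)(=O)N(Cc1ccc(C(C)(C)C)cc1)Cc1cccc(OCC(=O)O)c1` is measured in a functional assay on HEK293 cells for agonist activity at prostaglandin E2 receptor EP2 subtype (Rattus norvegicus), read by cAMP accumulation (on this read-out higher numbers stand for an effect only at larger amounts of compound and lower numbers for an effect already at smaller amounts), at 58 nM, the highest of the three numbers shown. Compound 2 `CC(C)(C)c1ccc(CN(Cc2cccc(CCC(=O)O)c2)S(C)(=O)=O)cc1` stands nearest with 48 nM, within the scatter, while compound 1 `CC(C)(C)c1ccc(CN(Cc2cccc(CCC(=O)O)c2)S(=O)(=O)c2ccccc2)cc1` lies furthest at 0.2 nM. Compound 4 `CC(C)(C)c1ccc(CN(Cc2cccc(OCC(=O)O)c2)S(C)(=O)=O)cc1` differs from compound 3 by hydrogen in place of 1-methyl-1H-imidazol-2-yl on a saturated chain carbon bound to a sulfonyl sulfur. Going by the values given here, the only measured step on the sulfonyl group, a 240-fold higher number from compound 1 to compound 2 (2.38 log units; beyond the scatter), concerns phenyl to methyl and bears only indirectly. Compound 2 already carries methylsulfonyl together with a propanoic acid and gives a number within the scatter of compound 3, so the step of a 1.4-fold higher number from compound 3 to compound 4 (0.14 log units; within the scatter) is expected to be small, if any. Compound 4 is therefore estimated at 80 nM, between 25 nM and 250 nM.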

Compound 4, half-maximal effective concentration: 203 nM
Estimate against measurement, compound 4: 2.5-fold (0.40 log units) below; the measured number falls inside the stated range.
By their numbers in this assay, from the lowest: compound 1; then compounds 2 and 3 (each within the scatter of the next); then compound 4.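

In this assay, hydrogen in place of 1-methyl-1H-imidazol-2-yl on the saturated chain carbon bound to the sulfonyl sulfur gives a 3.5-fold higher number from compound 3 to compound 4 (0.54 log units; beyond the scatter), so this group is not neutral here. With methylsulfonyl held fixed, carboxymethoxy in place of 2-carboxyethyl gives a 4.2-fold higher number from compound 2 to compound 4 (0.63 log units; beyond the scatter), so the match between compound 2 and compound 3 did not mean the chain bearing the acid makes no difference. No measurement shown here explains either step.

From the compounds shown here alone, whether phenyl on the sulfonyl sulfur would bring as large a change alongside carboxymethoxy remains open, as does the effect of an amine or a longer chain on that saturated chain carbon.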